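A few compounds are considered here, and "the series" means these few. Any claim that something is new, unique, unknown or untested is made for them only; others in the source may bear on it.

For the measured compounds named here, in a functional assay on MCF7 cells (Homo sapiens) for cytotoxicity, read by WST assay, with a stated time of 72 h (on this read-out higher numbers stand for weaker inhibition and lower numbers for stronger inhibition), three compounds sharing one core have numbers so far: compound 1 `Cc1ccc(C2(c3ccc(O)cc3)C(=O)Nc3c2ccc(F)c3F)cc1` gives 1.7 nM, compound 2 `O=C1Nc2c(ccc(F)c2F)C1(c1ccc(O)cc1)c1ccc(F)c(F)c1` gives 7.8 nM, and compound 3 `O=C1Nc2c(ccc(F)c2F)C1(c1ccncc1)c1ccc(O)cc1` gives 37 nM. Compound 3 therefore has the highest number and the weakest inhibition of the three. Compound 4 `O=C1Nc2c(ccc(F)c2F)C1(c1ccc(O)cc1)c1cccnc1` differs from it in one place: pyridin-3-yl in place of pyridin-4-yl on a saturated ring carbon, with pyridin-3-yl in place of pyridin-4-yl on a saturated ring carbon. The nearest evidence comes from changes at that same carbon: the large 22-fold higher number from compound 1 to compound 3 (1.34 log units; beyond the scatter) and the modest 4.7-fold higher number from compound 2 to compound 3 (0.68 log units; beyond the scatter). Neither exchanges one of these pyridinyl groups for the other, so the direction remains uncertain. In this assay, a smaller change, not beyond the scatter, is expected: an estimated 1.5-fold lower number from compound 3 to compound 4 (0.17 log units; within the scatter). Compound 4 is estimated at 25 nM, with an expected range from 8 nM to 80 nM.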

Compound 4, half-maximal inhibitory concentration: 63 nM
For compound 4 the middle estimate is 2.5-fold (0.40 log units) below the measured one, and the stated range covers the measured number.
By their numbers in this assay, from the lowest: compound 1; then compound 2; then compounds 3 and 4 (each within the scatter of the next).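

Exchanging pyridin-4-yl for pyridin-3-yl on the saturated ring carbon gives a 1.7-fold higher number from compound 3 to compound 4 (0.23 log units; within the scatter), so this assay does not separate the two pyridinyl groups. The gap to the benzene-ring compounds appears with this second pyridinyl group too: an 8.1-fold higher number from compound 2 to compound 4 (0.91 log units; beyond the scatter) and a 37-fold higher number from compound 1 to compound 4 (1.57 log units; beyond the scatter), so it is not confined to pyridin-4-yl. No measurement is available that would explain these numbers. Still open, on these data alone, is how pyridin-2-yl, or a phenyl ring carrying an amine or a carboxylic acid, would behave on this carbon.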